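Changing the aryl group on the ring amine nitrogen

The compounds below may be only part of what the source reports. "The series", "measured", "known", "first", "only" and "open" are said of these compounds alone.

Compounds measured so far:
compound 1 `CCC1(CCCN2CCN(c3cccc(Cl)c3)CC2)C(=O)Nc2ccccc21` gives 21 nM
compound 2 `CC(C)CC1(CCCCN2CCN(c3cccc(Cl)c3)CC2)C(=O)Nc2ccccc21` gives 1.8 nM
compound 3 `CCC1(CCCCN2CCN(c3ccc(OC)cc3)CC2)C(=O)Nc2ccccc21` gives 25.4 nM

In an assay on CHO cells for displacement of a labelled ligand from 5-hydroxytryptamine receptor 7 (Homo sapiens) (a higher number here means a weaker inhibitor, a lower number a stronger inhibitor), compound 3 gives the highest of the three numbers, but its gap to compound 1 lies within the scatter, whereas compound 2 sits well beyond it with a far lower number. Compound 4 `CCC1(CCCCN2CCN(c3ccc(C)c(Cl)c3)CC2)C(=O)Nc2ccccc21` differs from compound 3 by 3-chloro-4-methylphenyl in place of 4-methoxyphenyl on an amine nitrogen in a ring. Within the data shown here, no pair of measured compounds isolates this change. Compounds 1 and 2, which both carry a 3-chlorophenyl on that nitrogen, give lower numbers than compound 3, though each differs from it elsewhere as well. A moderate step down, beyond the scatter, is expected, a 3.2-fold lower number from compound 3 to compound 4 (0.50 log units; beyond the scatter). Compound 4 is estimated at 8 nM, within 3 nM to 25 nM.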

Compound 4, inhibition constant: 0.66 nM
For compound 4 the middle estimate is 12-fold (1.08 log units) above the measured one, and the stated range ends above it.
By their numbers in this assay, from the lowest: compound 4; then compound 2; then compounds 1 and 3 (each within the scatter of the next).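

Putting 3-chloro-4-methylphenyl in place of 4-methoxyphenyl on the amine nitrogen in the ring gives a 38-fold lower number from compound 3 to compound 4 (1.59 log units; beyond the scatter) in this assay. Among these compounds, this is the first comparison here that isolates this position, and it shows that the aryl group alone can shift the number well beyond the scatter. Nothing measured here explains the size of this step.

On these data alone, it remains open whether the chlorine, the methyl or the loss of the methoxy carries the step. As far as these compounds go, how an unsubstituted phenyl or a pyridyl ring on that nitrogen would compare also remains open.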